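Dropping a Fluoro Atom in a Series of Weak Cytotoxins

The source may hold more compounds than are shown below. What is called first, only, known or untested is meant among the compounds shown, and "the series" means these compounds.

Compound 1 `COc1ccc2c(C(=O)/C(C#N)=C/c3c[nH]c4cc(F)ccc34)c[nH]c2c1` and compound 2 `COc1ccc2c(C(=O)/C(C#N)=C/c3c[nH]c4ccccc34)c[nH]c2c1` are built on one shared core and differ in a single place, (hydrogen in place of fluoro on an aromatic carbon). In a functional assay on PC-3 cells (Homo sapiens) for cytotoxicity, read by WST assay, with a stated time of 24 h (a higher number here means a weaker inhibitor, a lower number a stronger inhibitor), compound 1 gives 36000 nM. For compound 2 this assay reports only a limit, > 50000 nM. The step of an at least 1.3-fold higher number from compound 1 to compound 2 (0.14 log units; that floor lies within the scatter) is thus known only as a floor, and that floor lies within the usual scatter of this assay; where compound 2 sits is marked by the limit of > 50000 nM in this assay, at which 2 of the 3 values shown sit.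

Compound 3 `COc1ccc(Cn2cc(/C=C(\C#N)C(=O)c3c[nH]c4cc(F)ccc34)c3ccccc32)cc1` rests on a second core. The difference between the two cores is not broken down here. For compound 3 this assay again reports only a limit, > 50000 nM.

Compound 4 `COc1ccc(Cn2cc(/C=C(\C#N)C(=O)c3c[nH]c4ccccc34)c3ccccc32)cc1` has not yet been measured. It differs from compound 3 by hydrogen in place of fluoro on an aromatic carbon. For the measured compounds named here, this is the same change as the one from compound 1 to compound 2, made at the same place on the second core.

Given that compound 3 already stands at the limit shown by the limit of > 50000 nM in this assay, at which 2 of the 3 values shown sit, and that the measured step of an at least 1.3-fold higher number from compound 1 to compound 2 (0.14 log units; that floor lies within the scatter) gave no more than a small rise, compound 4 is expected to stay at or beyond that limit. The expected step that the limit leaves unreadable from compound 3 to compound 4 is therefore small in its own right, though its floor cannot be fixed from a limit. The estimate for compound 4 is 80000 nM, with an expected range from 40000 nM to 200000 nM, and this assay is expected most often to report only a limit again for compound 4.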

Compound 4, half-maximal inhibitory concentration: > 50000 nM
Compound 4 was reported as a limit; the forecaster's own chance of this, stated with the estimate: 90%; the middle value does not contradict the limit.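

In this assay compound 4 also gives only a limit, > 50000 nM, and since compound 3 is likewise known only as a limit, no step can be read between compound 3 and compound 4. The compounds shown leave open how far beyond the limit compound 2, compound 3 and compound 4 actually lie, and so whether replacing fluoro with hydrogen changes cytotoxicity on either core.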